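Shortening the Acid Side Chain in a Sulfonyl Hydrazide Series

The source may hold more compounds than are shown below. What is called first, only, known or untested is meant among the compounds shown, and "the series" means these compounds.

Compound 3 `O=C(O)COc1ccc(S(=O)(=O)NNc2ccc(Br)cc2)cc1` gives 125 nM in an assay for inhibition of Indoleamine 2,3-dioxygenase 1 (Homo sapiens), read by spectrophotometry, with stated times of 1 h and 4 h (a higher number here means a weaker inhibitor, a lower number a stronger inhibitor), the second highest of three numbers, though all three sit within the usual scatter of one another. Compound 1 `O=S(=O)(NNc1ccc(Br)cc1)c1ccccc1` gives 172 nM and compound 2 `COC(=O)CCc1ccc(S(=O)(=O)NNc2ccc(Br)cc2)cc1` gives 121 nM. Compound 4 `O=C(O)c1ccc(S(=O)(=O)NNc2ccc(Br)cc2)cc1` differs from compound 3 by carboxy in place of carboxymethoxy on an aromatic carbon. Among the compounds with values here, the steps that bear on this change are a 1.4-fold lower number from compound 1 to compound 3 (0.14 log units; within the scatter) and a 1.0-fold higher number from compound 2 to compound 3 (0.01 log units; within the scatter), both within the scatter, so the groups tried on this aromatic carbon have so far made no real difference. The expected step to compound 4 in this assay is therefore a 1.0-fold higher number from compound 3 to compound 4 (0.02 log units; within the scatter), none beyond the scatter. Compound 4 is estimated at 130 nM, in a range from 60 nM to 280 nM.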

Compound 4, half-maximal inhibitory concentration: 61 nM
Estimate against measurement, compound 4: 2.1-fold (0.33 log units) above, within the range that was stated.
By their numbers in this assay, from the lowest: compounds 4, 2, 3 and 1 (each within the scatter of the next, the first and the last beyond it).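

In this assay, within the data shown here, carboxy is the first group on this aromatic carbon to give a step beyond the scatter, with a 2.0-fold lower number from compound 3 to compound 4 (0.31 log units; beyond the scatter) and a 2.8-fold lower number from compound 1 to compound 4 (0.45 log units; beyond the scatter), though both steps are modest. The shorter acid side chain therefore does better than carboxymethoxy, but the pattern is not clean: compound 2 has no free acid, and a 2.0-fold lower number from compound 2 to compound 4 (0.30 log units; within the scatter) stays within the scatter. Nothing available explains this difference. On these data alone, it remains open whether the free acid itself matters, which the methyl ester of compound 4 could test, and how an amine or a nitrile on this carbon would compare.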